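Ethyl for methyl on the aryl-triazole arm

This account rests on a few compounds, and the source may have more. Where it says the series, first, only, none or still open, it means among the compounds named here.

Measured compounds in a functional assay on MCF7 cells (Homo sapiens) for antiproliferative activity, read by MTT assay, with a stated time of 48 h; a higher number here means a weaker inhibitor, a lower number a stronger inhibitor:
compound 1 `N#CC1=C(N)Oc2c(c3nc4ccccc4nc3c3ccccc23)C12C(=O)N(Cc1cnnn1-c1ccc(N)cc1)c1ccccc12` gives the assay limit > 50000 nM.
compound 2 `Cc1ccc(-n2nncc2CN2C(=O)C3(C(C#N)=C(N)Oc4c3c3nc5ccccc5nc3c3ccccc43)c3ccccc32)c(C)c1` gives the assay limit > 50000 nM.
compound 3 `Cc1ccccc1-n1nncc1CN1C(=O)C2(C(C#N)=C(N)Oc3c(N)cc4nc5ccccc5nc4c32)c2ccccc21` gives the assay limit > 50000 nM.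

Compound 3 stands at the assay limit, and no number inside the measured range exists for it; the same holds for every compound of this set, as the limit of > 50000 nM in this assay, at which 3 of the 3 values shown sit, records. Going by the values given here, the only step between two measured compounds that differ in one place, a step that the two limits leave unreadable from compound 1 to compound 2, is consequently not readable in size, and it tells nothing about direction either.

Compound 4 `CCc1ccccc1-n1nncc1CN1C(=O)C2(C(C#N)=C(N)Oc3c(N)cc4nc5ccccc5nc4c32)c2ccccc21` differs from compound 3 by methyl in place of hydrogen on a saturated chain carbon bound to an aromatic carbon. No measured step bears on this change, and the single step shown cannot be read at all. The expectation for the step from compound 3 to compound 4 in this assay is therefore none beyond the scatter, written as a step that the limit leaves unreadable from compound 3 to compound 4. Compound 4 is expected to sit at about 60000 nM, within 20000 nM to 200000 nM, and most likely to be reported again only as a limit rather than as a number.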

Compound 4, half-maximal inhibitory concentration: 24600 nM
Beside the measured number, compound 4's estimate is 2.4-fold (0.39 log units) above it, within the range that was stated.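

Methyl to ethyl, which turns 2-methylphenyl into 2-ethylphenyl on a saturated chain carbon bound to an aromatic carbon, gives in this assay an at least 2.0-fold lower number from compound 3 to compound 4 (0.30 log units; that floor lies within the scatter), the first step in this set with any readable size, and that size is only a floor. The value of compound 3, > 50000 nM, is a limit of the assay and not a number. Compound 4 is the one compound shown with a number inside the measured range, which gives this position its first readable handle: the limit of > 50000 nM in this assay, at which 3 of the 4 values shown sit.

As far as these compounds go, how far the step reaches past its floor stays open, as does what a longer chain such as propyl, an amine or a carboxylic acid would give at this place. The only other step, between compound 1 and compound 2, cannot be read, so nothing shown says whether this change would carry over to the core of compound 1.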